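This account rests on a few compounds, and the source may have more. Where it says the series, first, only, none or still open, it means among the compounds named here.

Measured in an ADME assay on cells (Macrophage, Homo sapiens) for cytotoxicity, read by MTT assay, with a stated time of 24 h; on this read-out lower numbers stand for higher toxicity in this test and higher numbers for lower toxicity in this test:
- Compound 1, `CC(O)Cn1c([N+](=O)[O-])cnc1/C=C/c1ccc(Br)cc1`: 550 nM
- Compound 2, `CC(O)Cn1c([N+](=O)[O-])cnc1/C=C/c1cccc(F)c1`: 1030 nM
- Compound 3, `CC(O)Cn1c([N+](=O)[O-])cnc1/C=C/c1ccc(F)cc1`: 420 nM

Compound 3 has the lowest of the three numbers in this assay. Its gap to compound 1 is small, a 1.3-fold lower number from compound 1 to compound 3 (0.12 log units; within the scatter), so the two cannot be told apart; its gap to compound 2 is larger, a 2.5-fold lower number from compound 2 to compound 3 (0.39 log units; beyond the scatter), and that one stands out from the scatter.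

Compound 4, `CC(O)Cn1c([N+](=O)[O-])cnc1/C=C/c1cccc(Br)c1`, is not yet measured. It differs from compound 3 in one place: 3-bromophenyl in place of 4-fluorophenyl on a double-bonded chain carbon bound to a double-bonded chain carbon. This single change combines two of the steps already seen, read backwards. One is the swap of halogen on the ring, a 1.3-fold lower number from compound 1 to compound 3 (0.12 log units; within the scatter), which was small. The other is the move of the halogen to the 3-position, a 2.5-fold lower number from compound 2 to compound 3 (0.39 log units; beyond the scatter), which was modest. Both point the same way, so compound 4 is expected to give a modestly higher number than compound 3, a step of about a 2.6-fold higher number from compound 3 to compound 4 (0.42 log units; beyond the scatter). Compound 4 is therefore estimated at 1100 nM, with a likely range from 500 nM to 2500 nM.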

Compound 4, half-maximal cytotoxic concentration: 620 nM
Beside the measured number, compound 4's estimate is 1.8-fold (0.25 log units) above it; the measured number falls inside the stated range.
By their numbers in this assay, from the lowest: compounds 3, 1, 4 and 2 (each within the scatter of the next, the first and the last beyond it).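

Bromo and fluoro no longer behave alike at this position: moving bromo from 4-bromophenyl to 3-bromophenyl gives a 1.1-fold higher number from compound 1 to compound 4 (0.05 log units; within the scatter), so the gap seen between the two fluorinated isomers, a 2.5-fold lower number from compound 2 to compound 3 (0.39 log units; beyond the scatter), does not reappear with bromo. Changing both the halogen and its place at once also stays small, at a 1.5-fold higher number from compound 3 to compound 4 (0.17 log units; within the scatter), so the two earlier steps did not simply add up. Swapping the halogen now looks small on the 3-substituted ring too, at a 1.7-fold lower number from compound 2 to compound 4 (0.22 log units; within the scatter), and the two halogen swaps agree: the same change on two cores in this assay, a 1.3-fold lower number (0.12 log units; within the scatter) from compound 1 to compound 3 and a 1.7-fold higher number (0.22 log units; within the scatter) from compound 4 to compound 2, 2.2-fold (0.34 log units) apart, within the scatter of two such steps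

All four compounds carry a single halogen on the phenyl ring. On these data alone, how the number in this assay would respond to an amine, a carboxylic acid or a methoxy group there, or to a plain phenyl, remains open.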